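A Furan-3-yl Group Replaces a Non-Aromatic Ring

The source may hold more compounds than are shown below. What is called first, only, known or untested is meant among the compounds shown, and "the series" means these compounds.

In a functional assay on HT-29 cells (Homo sapiens) for antiproliferative activity, read by XTT assay, with a stated time of 72 h (a lower number here means a stronger inhibitor, a higher number a weaker inhibitor), compound 1 `C=C(C)CCC[C@]1(C)C2=CCC[C@](C)(C[C@@H](O)C3=CC(=O)OC3O)[C@H]2CC[C@H]1C` gives 2300 nM, and compound 2 `C=C(C)CCC[C@]1(C)C2=CCC[C@](C)(C[C@H](O)C3=CC(=O)OC3O)[C@H]2CC[C@H]1C` gives 3000 nM, so the two values lie within the scatter of each other. Compound 3 `C=C(C)CCC[C@]1(C)C2=CCC[C@](C)(C[C@@H](O)c3ccoc3)[C@H]2CC[C@H]1C` differs from compound 2 in one place: a group of 7 heavy atoms (5 carbon, 2 oxygen; one five-membered aromatic ring with 1 hetero atom) in place of a group of 9 heavy atoms (5 carbon, 4 oxygen; one five-membered non-aromatic ring with 1 hetero atom), on a saturated chain carbon bound to a saturated ring carbon. The new group is (furan-3-yl)(hydroxy)methyl. Going by the values given here, only one measured step exists, a 1.3-fold higher number from compound 1 to compound 2 (0.12 log units; within the scatter), and it alters a single stereocentre while both compounds keep the five-membered non-aromatic ring. That step therefore gives no direct measure of the exchange, and it sets no size for it. A moderately higher number is expected, but with wide uncertainty. In this assay the expected change is a 2.3-fold higher number from compound 2 to compound 3 (0.37 log units; beyond the scatter). For compound 3 the estimated value is 7000 nM, with an expected range of 2500 nM to 25000 nM.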

Compound 3, half-maximal inhibitory concentration: 63100 nM
The estimate for compound 3 lay 9.0-fold (0.95 log units) below the measured number; the measured number lies above the stated range.
By their numbers in this assay, from the lowest: compounds 1 and 2 (each within the scatter of the next); then compound 3.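

Exchanging the five-membered non-aromatic ring for the furan-3-yl group is the first change among these compounds to move the number beyond the scatter in this assay, with a 21-fold higher number from compound 2 to compound 3 (1.32 log units; beyond the scatter) and a 27-fold higher number from compound 1 to compound 3 (1.44 log units; beyond the scatter). Both steps are large, so the loss appears whichever of the two drawn configurations at the saturated chain carbon is the starting point. At this position, the exchange of the ring therefore counts for far more than the stereocentre did, although nothing shown gives a reason for the size of the step.

From the compounds shown here alone, the ring hydroxyl, the carbonyl and the ring double bond all leave together, and which of them carries the difference stays open. Going by these compounds, it is also open whether a carboxylic acid or a phenyl group in that place would stand nearer compound 2 or compound 3.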